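The source may hold more compounds than are shown below. What is called first, only, known or untested is meant among the compounds shown, and "the series" means these compounds.

Compound 1 `CCOC(=O)c1ccc(NC(=O)CSC(=S)N[C@H]2CCOC2=O)cc1` gives 64900 nM in a functional assay on SMMC-7721 cells (Homo sapiens) for cytotoxicity, read by MTT assay, with a stated time of 72 h; on this read-out lower numbers stand for stronger inhibition and higher numbers for weaker inhibition.
Compound 2 `O=C(CSC(=S)N[C@H]1CCOC1=O)Nc1ccc(C(=O)/C=C/c2ccc(Cl)cc2)cc1` reaches only the limit of > 128000 nM in this assay.
Compound 3 `O=C(CSC(=S)N[C@H]1CCOC1=O)Nc1ccc(C(=O)/C=C/c2ccccc2)cc1` also reaches only the limit of > 128000 nM in this assay.

Compound 3 therefore stands at the ceiling of the series, where (the limit of > 128000 nM in this assay, at which 2 of the 3 values shown sit); no number is known for it, only that its half-maximal inhibitory concentration lies beyond that limit. The two steps from compound 1, an at least 1.9-fold higher number from compound 1 to compound 2 (0.29 log units; that floor lies within the scatter) and an at least 1.9-fold higher number from compound 1 to compound 3 (0.29 log units; that floor lies within the scatter), only show that replacing ethoxy by either styryl group drives the value out of the measurable window. The step that the two limits leave unreadable from compound 2 to compound 3, the only one that touches a chloro substituent, gives no size at all, since both ends are limits.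

Compound 4 `O=C(CSC(=S)N[C@H]1CCOC1=O)Nc1ccc(C(=O)/C=C/c2ccccc2Cl)cc1` differs from compound 3 by chloro in place of hydrogen on an aromatic carbon. Within the data shown here, with both neighbours at the limit and the single chloro step unreadable, no shift beyond the scatter is expected, so the step that the limit leaves unreadable from compound 3 to compound 4 is estimated as flat. Compound 4 is expected at 160000 nM, within 60000 nM to 450000 nM, and most likely to be reported again only as a limit in this assay.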

Compound 4, half-maximal inhibitory concentration: 20400 nM
The estimate for compound 4 lay 7.8-fold (0.89 log units) above the measured number; the measured number lies below the stated range.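

In this assay, chloro on the aromatic carbon ortho to a large group gives an at least 6.2-fold lower number from compound 3 to compound 4 (0.79 log units; beyond the scatter), and 2-chlorophenyl in place of 4-chlorophenyl gives an at least 6.2-fold lower number from compound 2 to compound 4 (0.79 log units; beyond the scatter), so this position responds to chloro and the place of the chloro on the ring matters. Both sizes are floors, because compound 2 and compound 3 are known only as limits: the limit of > 128000 nM in this assay, at which 2 of the 4 values shown sit. Against the ethoxy group, 2-(2-chlorophenyl)ethenyl gives a 3.2-fold lower number from compound 1 to compound 4 (0.50 log units; beyond the scatter), so a styryl-type group need not push the value out of the measurable window.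

As far as these compounds go, whether fluoro, bromo, methyl or methoxy on that same aromatic carbon would act like chloro stays open. So does the effect of a second chloro on this ring.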